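A few compounds are considered here, and "the series" means these few. Any claim that something is new, unique, unknown or untested is made for them only; others in the source may bear on it.

Measured compounds:
compound 1, `COc1ccc(-c2nc3sccn3c2/C=N/OCc2ccc(Cl)c(Cl)c2)cc1`, gives 490 nM in an assay on HepG2 cells for agonist activity at nuclear receptor subfamily 1 group I member 3 (Homo sapiens), read by a luciferase reporter, with a stated time of 23 h; a higher number here means that more compound is needed for the effect, a lower number that less compound is needed
compound 2, `Clc1ccc(CO/N=C/c2c(-c3ccc(-c4ccccc4)cc3)nc3sccn23)cc1Cl`, gives "not active" (no number reported) in this assay

Both compounds share the same core and the same dichlorobenzyl oxime ether, and differ only in the group on the outer aromatic ring. Compound 1, carrying a methoxy there, gives a measurable value, 490 nM. Going by the values given here, compound 2, carrying a phenyl there, was reported as "not active" (no number reported) in this assay, so no number stands for it, and no step between it and any other compound can be sized.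

Compound 3, `FC(F)(F)c1ccc(-c2nc3sccn3c2/C=N/OCc2ccc(Cl)c(Cl)c2)cc1`, is the next step from compound 2: trifluoromethyl in place of phenyl on an aromatic carbon. Whether this recovers activity cannot be read from a measured pair. Among the compounds with values here, the only guide is that compound 1, which also has a small group at that position, gives 490 nM, while compound 2 with the larger phenyl gives none. On that basis compound 3 is expected to give a number rather than no effect, roughly in the region where compound 1 sits, estimated at 700 nM with a range from 150 nM to 3500 nM, though a report of no activity remains a real possibility.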

Compound 3, half-maximal effective concentration: 880 nM
Compound 3: middle estimate off by 1.3-fold (0.10 log units), on the low side; measured number inside the range.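

In this assay, putting trifluoromethyl in place of methoxy on the same aromatic carbon gives a 1.8-fold higher number from compound 1 to compound 3 (0.25 log units; within the scatter) and so leaves the value effectively unchanged. A number at this position is therefore not tied to methoxy alone: two quite different groups both give one, while compound 2 with phenyl there gives "not active" (no number reported) in the same test, and this contrast now rests on two measured compounds instead of one. Nothing measured here gives a reason for the difference between phenyl and the other two groups.

The compounds shown leave open how much of the phenyl group has to go before a number returns, for instance whether a cyclohexyl ring or a longer chain such as butoxy at this place gives a value or none. They also leave open whether an amine or a carboxylic acid on this carbon would fit the same picture as methoxy and trifluoromethyl, or would behave like phenyl instead.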